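The source may report more compounds than this note shows. Statements on the series, on what has been measured and on what is new or still open speak of the compounds shown alone.

Of the compounds shown here, three built on one shared core have been measured in a functional assay on AS49-RAW cells (Homo sapiens) for antiproliferative activity, read by sulforhodamine B assay, with a stated time of 48 h; a lower number here means a stronger inhibitor, a higher number a weaker inhibitor. Compound 1 `Nc1ccc(S(=O)(=O)Nc2ccnc3cc(C(F)(F)F)ccc23)cc1` gives 29200 nM. Compound 2 `NS(=O)(=O)c1ccc(N/C(S)=N\c2ccnc3cc(C(F)(F)F)ccc23)cc1` gives 36600 nM, and compound 3 `Cc1noc(NS(=O)(=O)c2ccc(N/C(S)=N\c3ccnc4cc(C(F)(F)F)ccc34)cc2)c1C` gives 34000 nM. On these numbers compound 3 stands second highest of the three; its nearest neighbour is compound 2 and its furthest is compound 1, yet both gaps lie within the scatter, so the three cannot be told apart with confidence.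

Compound 4 `Cc1cc(C)nc(NS(=O)(=O)c2ccc(N/C(S)=N\c3ccnc4cc(C(F)(F)F)ccc34)cc2)n1` differs from compound 3 in one place: 4,6-dimethylpyrimidin-2-yl in place of 3,4-dimethyl-1,2-oxazol-5-yl on a sulfonamide nitrogen. A single measured step bears on this, a 1.1-fold lower number from compound 2 to compound 3 (0.03 log units; within the scatter), in which a group was placed on the same sulfonamide nitrogen and the number stayed within the scatter. Among the measured compounds shown here, no measured pair compares two different groups on that nitrogen, so the effect of exchanging one for another has not been seen directly.

Since the step of a 1.1-fold lower number from compound 2 to compound 3 (0.03 log units; within the scatter) lay within the scatter, the expectation for compound 4 is a step of no change at the digits printed from compound 3 to compound 4 (within the scatter), none beyond the scatter. Compound 4 is therefore estimated at 34000 nM, with a range from 17000 nM to 68000 nM.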

Compound 4, half-maximal inhibitory concentration: 43400 nM
Estimate against measurement, compound 4: 1.3-fold (0.11 log units) below; measured number inside the range.
By their numbers in this assay, from the lowest: compounds 1, 3, 2 and 4 (each within the scatter of the next).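

Among the compounds shown here, exchanging 3,4-dimethyl-1,2-oxazol-5-yl for 4,6-dimethylpyrimidin-2-yl on the sulfonamide nitrogen gives, in this assay, a 1.3-fold higher number from compound 3 to compound 4 (0.11 log units; within the scatter), so this is the first direct comparison of two different groups at this position, and a five-membered aromatic ring and a six-membered one cannot be told apart here. Measured against hydrogen on the same nitrogen, the 4,6-dimethylpyrimidin-2-yl group gives a 1.2-fold higher number from compound 2 to compound 4 (0.07 log units; within the scatter), which means that hydrogen and both ring groups now read alike in this assay, even though the ring groups add several heavy atoms. No accompanying measurement bears on why the numbers stay so close.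

The compounds shown carry only hydrogen or one of these two dimethyl-substituted aromatic rings on this nitrogen, so it remains open whether a different kind of group, such as an acetyl group, a longer alkyl chain, or a ring bearing a carboxylic acid or an amine, would give a number beyond the scatter. Going by these compounds, it also remains open whether any change at this position can produce a real difference in this cell assay, or whether such a difference would need a change elsewhere on the shared core.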